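This account rests on a few compounds, and the source may have more. Where it says the series, first, only, none or still open, it means among the compounds named here.

Three compounds share one core and differ only in the group bound to the sulfonyl sulfur. Compound 1 `N#Cc1ccc(O[C@H]2CN(S(=O)(=O)c3ccc(Cl)cc3)C[C@@]2(O)CO)cc1F` carries a 4-chlorophenyl there, and in an ADME assay on the whole organism (Rattus norvegicus, strain Sprague-Dawley) for pharmacokinetics, read by LC-MS, with a stated time of 30 min, at a dose of 1 mg/kg by the intravenous route (a higher number here means faster removal of the compound, a lower number slower removal), compound 1 gives 54 mL/min/kg. Compound 2 `N#Cc1ccc(O[C@H]2CN(S(=O)(=O)c3ccc(C(F)(F)F)cc3)C[C@@]2(O)CO)cc1F` carries a 4-(trifluoromethyl)phenyl, and in this assay compound 2 gives 50 mL/min/kg. Compound 3 `N#Cc1ccc(O[C@H]2CN(S(=O)(=O)c3ccc(Cl)cn3)C[C@@]2(O)CO)cc1F` carries a 5-chloropyridin-2-yl, and in this assay compound 3 gives 30 mL/min/kg, the lowest of the three numbers; yet a 1.8-fold lower number from compound 1 to compound 3 (0.26 log units; within the scatter) and a 1.7-fold lower number from compound 2 to compound 3 (0.22 log units; within the scatter), so compound 3 cannot be set apart from the other two. The remaining step is a 1.1-fold lower number from compound 1 to compound 2 (0.03 log units; within the scatter).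

Compound 4 `N#Cc1ccc(O[C@H]2CN(S(=O)(=O)c3ccc(Cl)cn3)C[C@@]2(O)CN)cc1F` keeps the 5-chloropyridin-2-yl of compound 3 and differs in another place: amino in place of hydroxy on a saturated chain carbon bound to a saturated ring carbon. None of the three measured steps touches this part of the molecule; each of them changes only the group on the sulfonyl sulfur, and each stays within the scatter. The measured steps therefore give no direct guide to a change from hydroxy to amino, and the only expectation that rests on these numbers is one of no step beyond the scatter. Compound 4 is thus expected to show no change at the digits printed from compound 3 to compound 4 (within the scatter), which gives an estimate of 30 mL/min/kg with a range from 15 mL/min/kg to 60 mL/min/kg.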

Compound 4, clearance: 45 mL/min/kg
Estimate against measurement, compound 4: 1.5-fold (0.18 log units) below; measured number inside the range.
By their numbers in this assay, from the lowest: compounds 3, 4, 2 and 1 (each within the scatter of the next).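

The step from hydroxymethyl to aminomethyl is the first change shown away from the sulfonyl sulfur, and in this assay it reads as a 1.5-fold higher number from compound 3 to compound 4 (0.18 log units; within the scatter). So, on a saturated chain carbon bound to a saturated ring carbon, one heavy atom can be exchanged, oxygen for nitrogen, without a step that stands out from repeated measurements, which is also how the changes on the sulfonyl sulfur read. No measurement shown gives a reason for the size of this step, so a single small step is all this position offers so far.

On these data alone, whether a different group at this place, such as a dimethylamino group, a carboxylic acid or a longer chain like 2-hydroxyethyl, would move clearance beyond the scatter remains open. The exchange of hydroxy for amino is also shown only with the 5-chloropyridin-2-yl on the sulfonyl sulfur, so it remains open whether it would read the same with the 4-chlorophenyl or the 4-(trifluoromethyl)phenyl there.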